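The compounds below may be only part of what the source reports. "The series", "measured", "known", "first", "only" and "open" are said of these compounds alone.

Of the compounds shown here, three sharing one core have been tested in a functional assay on MCF7 cells (Homo sapiens) for cytotoxicity, read by MTT assay, with a stated time of 48 h; on this read-out higher numbers stand for weaker inhibition and lower numbers for stronger inhibition. Compound 1 `CNC(=O)CSc1nc2ccc(NC(=O)c3ccc(Cl)cc3)cc2s1` gives 29400 nM. Compound 2 `O=C(CSc1nc2ccc(NC(=O)c3ccc(Cl)cc3)cc2s1)NCc1ccc(Cl)cc1` gives 29300 nM, and compound 3 `O=C(CSc1nc2ccc(NC(=O)c3ccc(Cl)cc3)cc2s1)NCc1ccccc1` gives 25900 nM. These numbers sit close together: a 1.0-fold lower number from compound 1 to compound 2 (0.00 log units; within the scatter), a 1.1-fold lower number from compound 1 to compound 3 (0.06 log units; within the scatter), and a 1.1-fold lower number from compound 2 to compound 3 (0.05 log units; within the scatter). Compound 1 therefore stands among three values that cannot be told apart, and none of the three can be called stronger or weaker than another.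

Compound 4 `CNC(=O)CSc1nc2ccc(NC(=O)c3ccccc3OC)cc2s1` has not yet been measured. It differs from compound 1 in one place: 2-methoxyphenyl in place of 4-chlorophenyl on a carbonyl carbon. The three measured steps all alter a group on a saturated chain carbon bound to an amide-type nitrogen, or a chloro on an aromatic carbon within such a group; none of them touches the group on the carbonyl carbon. For the measured compounds named here, no measured step therefore bears directly on the change from compound 1 to compound 4. Going by the values given here, the only guide is that every change tried so far left the number within the scatter, so the expected step for compound 4 is none beyond the scatter, a 1.0-fold higher number from compound 1 to compound 4 (0.01 log units; within the scatter), with wide uncertainty. The estimate for compound 4 in this assay is 30000 nM, expected to fall between 10000 nM and 90000 nM.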

Compound 4, half-maximal inhibitory concentration: 23400 nM
Beside the measured number, compound 4's estimate is 1.3-fold (0.11 log units) above it; the measured number falls inside the stated range.
By their numbers in this assay, from the lowest: compounds 4, 3, 2 and 1 (each within the scatter of the next).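

For the compounds shown here, the group on the carbonyl carbon is unchanged across the earlier compounds, and in this assay replacing 4-chlorophenyl with 2-methoxyphenyl gives a 1.3-fold lower number from compound 1 to compound 4 (0.10 log units; within the scatter) and so stays within the scatter. This site therefore joins the group on the amide-type nitrogen as a part of the molecule where the changes shown do not separate the compounds. The exchange removes the chlorine and adds an oxygen, taking the group from no hydrogen-bond acceptors to one, yet the number cannot be told apart from that of compound 1, and no measurement available here bears on why.

The compounds shown leave open whether any group on the carbonyl carbon can move the number beyond the scatter, such as a ring carrying an amine or a carboxylic acid. They also cannot divide this single exchange into its two parts, and an unsubstituted phenyl on the carbonyl carbon would be a direct comparison for both compound 1 and compound 4.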